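From ethoxy to butoxy on compound 1

The source may report more compounds than this note shows. Statements on the series, on what has been measured and on what is new or still open speak of the compounds shown alone.

Compound 1 `CCOC(=O)c1cnc(N2CCN(C(=O)NS(=O)(=O)c3ccc(Cl)s3)CC2)c(Cl)c1`: > 70000 mL.min-1.g-1
Compound 2 `CCOC(=O)c1cnc(N2CCN(C(=O)NS(=O)(=O)c3ccccc3C)CC2)c(Cl)c1`: > 70000 mL.min-1.g-1
Compound 3 `CCOC(=O)c1cnc(N2CCN(C(=O)NS(=O)(=O)c3ccc(C)cc3)CC2)c(Cl)c1`: > 70000 mL.min-1.g-1

In an ADME assay on microsomes from liver (Homo sapiens) for metabolic stability, read by LC-MS, using NADPH (a lower number here means slower removal, a higher number faster removal of the compound), compound 1 gives > 70000 mL.min-1.g-1 as a limit, not a number. Compound 1 stands at the limit of > 70000 mL.min-1.g-1 in this assay, at which 3 of the 3 values shown sit, and so cannot be ranked against compound 2 or compound 3. Compound 4 `CCCCOC(=O)c1cnc(N2CCN(C(=O)NS(=O)(=O)c3ccc(Cl)s3)CC2)c(Cl)c1` differs from compound 1 by ethyl in place of hydrogen on a saturated chain carbon, two bonds along the chain from an oxygen next to a carbonyl group and so turns ethoxy into butoxy. The measured steps a step that the two limits leave unreadable from compound 1 to compound 2 and a step that the two limits leave unreadable from compound 1 to compound 3 and a step that the two limits leave unreadable from compound 2 to compound 3 all lie on the sulfonyl sulfur and have no readable size, so they give no measure for this change. Among the compounds with values here, no sized step or firm direction can therefore be expected in this assay on this evidence. For compound 4 the expected step is a step that the limit leaves unreadable from compound 1 to compound 4 and it is only a rough estimate. Compound 4 is expected at 90000 mL.min-1.g-1 with an estimated range from 40000 mL.min-1.g-1 to 200000 mL.min-1.g-1 and may well turn out to be only a limit.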

Compound 4, intrinsic clearance in microsomes in the Homo sapiens assay: > 70000 mL.min-1.g-1
Compound 4 was reported as a limit (the forecaster's own chance of this, stated with the estimate: 85%); the middle value lies beyond the limit too.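

No step can be read from compound 1 to compound 4 in the Homo sapiens assay, as both values are limits of the assay: the limit of > 70000 mL.min-1.g-1 in the Homo sapiens assay, at which 4 of the 4 values shown sit.

In a physicochemical assay (on this read-out lower numbers stand for a less stable compound and higher numbers for a more stable compound), compound 1 gives "stable" (no number reported) and compound 4 gives "stable" (no number reported), so no step can be read there either. The compounds shown leave open whether butoxy in place of ethoxy alters the rate of removal at all.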